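A few compounds are considered here, and "the series" means these few. Any claim that something is new, unique, unknown or untested is made for them only; others in the source may bear on it.

Measured so far:
compound 1 `CNC(=O)c1cc(-c2cnc(NCc3c(F)ccc4c3CCO4)c3cn[nH]c(=O)c23)n(C)n1` — 2.1
compound 2 `Cc1ncccc1-c1cnc(NCc2c(F)ccc3c2CCO3)c2n[nH]c(=O)n12` — 2.5

Two compounds have been run in a physicochemical assay for lipophilicity, using the shake flask method, in phosphate buffer, measured as octanol-water partition, with a stated time of 30 min, at pH 7.4; on this read-out higher numbers stand for higher lipophilicity and lower numbers for lower lipophilicity. Compound 1 gives 2.1, the lower of the two numbers, while compound 2 gives 2.5, a number that lies above compound 1 by more than the usual scatter of this assay.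

Compound 3 `Cc1ncc(-c2cnc(NCc3c(F)ccc4c3CCO4)c3cn[nH]c(=O)c23)n1C` has not yet been measured. It differs from compound 1 in one place: 1,2-dimethyl-1H-imidazol-5-yl in place of 1-methyl-3-(methylcarbamoyl)-1H-pyrazol-5-yl on an aromatic carbon. Within the data shown here, no measured pair shows this same change, so nothing here tells directly how large its effect is.

With the amide gone from the group that leaves, a step upward in this assay seems the more likely direction, but the group that enters is smaller and brings its own two acceptors, so the step from compound 1 to compound 3 is expected to be modest, a number 0.30 log units higher from compound 1 to compound 3 (within the scatter). Compound 3 is therefore estimated at 2.4, within a range from 1.8 to 3.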

Compound 3, distribution coefficient: 1.9
Estimate against measurement, compound 3: 0.50 log units above, within the range that was stated.
By their numbers in this assay, from the lowest: compounds 3 and 1 (each within the scatter of the next); then compound 2.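

At this aromatic carbon, para to a large group, 1,2-dimethyl-1H-imidazol-5-yl in place of 1-methyl-3-(methylcarbamoyl)-1H-pyrazol-5-yl gives a number 0.20 log units lower from compound 1 to compound 3 (within the scatter) in this assay. The first step read at this position therefore shows that a group with fewer heavy atoms and 0 hydrogen-bond donors can take the place of the methylcarbamoyl-bearing pyrazole without a change that this read-out can separate from the scatter. Nothing measured here explains this result.

Among these compounds, with only this one step at the position, it remains open how far the read-out can move there at all. Whether a five-membered aromatic ring carrying a carboxylic acid or an amine, or a longer alkyl chain in place of the methyl groups, would give a step beyond the scatter is also unsettled.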